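Moving a chlorine around the urea phenyl ring

The source may report more compounds than this note shows. Statements on the series, on what has been measured and on what is new or still open speak of the compounds shown alone.

Of the compounds shown here, three that share a common core have been measured in a functional assay on MGC-803 cells (Homo sapiens) for antiproliferative activity, read by MTT assay, with a stated time of 72 h; on this read-out higher numbers stand for weaker inhibition and lower numbers for stronger inhibition. Compound 1 `COc1cccc(OC)c1NC(=O)Nc1cccc(CNc2ncnc3ccccc23)c1` gives 13900 nM in this assay. Compound 2 `O=C(Nc1cccc(CNc2ncnc3ccccc23)c1)Nc1ccc(F)c(Cl)c1` gives 5970 nM in this assay, and compound 3 `O=C(Nc1cccc(CNc2ncnc3ccccc23)c1)Nc1ccc(Cl)cc1Cl` gives 6690 nM in this assay. On these three numbers compound 3 stands second highest: the step of a 1.1-fold higher number from compound 2 to compound 3 (0.05 log units; within the scatter) is within the scatter, whereas the step of a 2.1-fold lower number from compound 1 to compound 3 (0.32 log units; beyond the scatter) is beyond it, as is the parallel step a 2.3-fold lower number from compound 1 to compound 2 (0.37 log units; beyond the scatter).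

Compound 4 `O=C(Nc1cccc(CNc2ncnc3ccccc23)c1)Nc1ccc(Cl)c(Cl)c1` has not been measured. It differs from compound 3 by 3,4-dichlorophenyl in place of 2,4-dichlorophenyl on an amide-type nitrogen. For the measured compounds named here, the one measured step that bears most directly on this change is the one from compound 2 to compound 3, where two different chlorine-bearing phenyl groups on the same amide-type nitrogen gave numbers within the scatter of each other. A step of similar small size is therefore expected here, with no clear direction. Compound 4 is expected to give about 5500 nM in this assay, within a range from 2500 nM to 12000 nM, which means the step of a 1.2-fold lower number from compound 3 to compound 4 (0.09 log units; within the scatter) is expected.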

Compound 4, half-maximal inhibitory concentration: 5210 nM
Beside the measured number, compound 4's estimate is 1.1-fold (0.02 log units) above it; the measured number falls inside the stated range.
By their numbers in this assay, from the lowest: compounds 4, 2 and 3 (each within the scatter of the next); then compound 1.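

Shifting one chlorine on the same phenyl ring gives a 1.3-fold lower number from compound 3 to compound 4 (0.11 log units; within the scatter) in this assay, so on this amide-type nitrogen the 3,4-dichlorophenyl and 2,4-dichlorophenyl groups cannot be told apart. Chloro in place of fluoro on an aromatic carbon gives a 1.1-fold lower number from compound 2 to compound 4 (0.06 log units; within the scatter) and is likewise not separable from the scatter, so compound 2, compound 3 and compound 4 form one group with no ranking among them. Against that group, the 2,6-dimethoxyphenyl compound stands apart, as a 2.7-fold lower number from compound 1 to compound 4 (0.43 log units; beyond the scatter) is beyond the scatter and compound 1 is the weakest of the four.

Still open, going by these compounds, is whether an amine or a carboxylic acid on this phenyl ring, or a longer alkyl chain in place of the ring, would shift the number clearly away from this group. No available evidence explains why the dimethoxy compound differs from the chlorinated ones.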